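Sulfanyl-chain exchange in a triazolopyrimidine series: GES1 inhibition

This account rests on a few compounds, and the source may have more. Where it says the series, first, only, none or still open, it means among the compounds named here.

Measured in an ADME assay on GES1 cells (Homo sapiens) for inhibition, read by MTT assay, with a stated time of 72 h; a lower number here means a stronger inhibitor, a higher number a weaker inhibitor:
compound 1 `Cc1cc(Nc2cc(-c3ccccc3)[nH]n2)n2nc(SCc3nc4ccccc4[nH]3)nc2n1` gives 27800 nM
compound 2 `Cc1cc(Nc2ccn(Cc3ccc(C(F)(F)F)cc3)n2)n2nc(SCc3ccc(Br)cc3)nc2n1` gives 30200 nM
compound 3 `Cc1cc(Nc2ccn(Cc3ccccc3)n2)n2nc(SCc3ccc(Br)cc3)nc2n1` gives 44400 nM

Compound 1 sits at the low end of the three numbers, but its gaps to compound 2 and to compound 3 both fall within the scatter, so the three are not separable. Compound 4 `Cc1cc(Nc2cc(-c3ccccc3)[nH]n2)n2nc(SCC(=O)c3ccccc3)nc2n1` differs from compound 1 by benzoyl in place of 1H-benzimidazol-2-yl on a saturated chain carbon bound to a sulfur. For the measured compounds named here, the only single-point step measured, a 1.5-fold higher number from compound 2 to compound 3 (0.17 log units; within the scatter), concerns a different part of the molecule and leaves the sulfanyl chain untouched, so no measured step bears directly on the 1H-benzimidazol-2-yl to benzoyl exchange. All three measured compounds fall in a narrow band. Compound 4 is therefore expected to give 30000 nM, between 12000 nM and 80000 nM. The expected step is a 1.1-fold higher number from compound 1 to compound 4 (0.03 log units; within the scatter), i.e. none beyond the scatter.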

Compound 4, half-maximal inhibitory concentration: 33300 nM
Compound 4: middle estimate off by 1.1-fold (0.05 log units), on the low side, and the stated range covers the measured number.
By their numbers in this assay, from the lowest: compounds 1, 2, 4 and 3 (each within the scatter of the next).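

In this assay the exchange at this position gives a 1.2-fold higher number from compound 1 to compound 4 (0.08 log units; within the scatter), the first step read on the sulfanyl chain itself. Benzoyl in place of 1H-benzimidazol-2-yl drops the five-membered aromatic ring and the hydrogen-bond donor, yet the two compounds stay inseparable. No available measurement accounts for this result. From the compounds shown here alone, whether a carboxylic acid, an amine or a longer chain on the carbon bound to the sulfur would separate from compound 1 remains open. Going by these compounds, whether the same exchange reads alike on the core of compound 2 is also open.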